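A Larger Side Chain on Compound 3

This account rests on a few compounds, and the source may have more. Where it says the series, first, only, none or still open, it means among the compounds named here.

Of the compounds shown here, three with a shared core have been measured in a functional assay on K562 cells (Homo sapiens) for cytotoxicity, read by trypan blue exclusion, with a stated time of 96 h; on this read-out higher numbers stand for weaker inhibition and lower numbers for stronger inhibition. Compound 1 `COC(=O)C(F)(F)Nc1cc(CS(=O)(=O)/C=C/c2c(OC)cc(OC)cc2OC)ccc1OC` gives 250 nM, and compound 2 `COC(=O)C(C)(C)Nc1cc(CS(=O)(=O)/C=C/c2c(OC)cc(OC)cc2OC)ccc1OC` gives 800 nM. Compound 3 `COc1cc(OC)c(/C=C/S(=O)(=O)Cc2ccc(OC)c(N[C@@H](C)C(=O)O)c2)c(OC)c1` gives 15 nM, the lowest number of the three and therefore the strongest inhibition so far.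

Compound 4 `COc1cc(OC)c(/C=C/S(=O)(=O)Cc2ccc(OC)c(NC(C(=O)O)c3ccc(Br)cc3)c2)c(OC)c1` has (4-bromophenyl)(carboxy)methyl in place of 1-carboxyethyl on a nitrogen on an aromatic ring.

All three measured steps involve a change on this same nitrogen. Exchanging one methoxycarbonyl-bearing group for another gave a 3.2-fold higher number from compound 1 to compound 2 (0.51 log units; beyond the scatter), a modest change. Moving to the carboxy-bearing group of compound 3 gave larger changes: a 17-fold lower number from compound 1 to compound 3 (1.22 log units; beyond the scatter) and a 53-fold lower number from compound 2 to compound 3 (1.73 log units; beyond the scatter). Compound 4 keeps the carboxy group, however, so these two large steps are a poor guide to it. For the measured compounds named here, no measured compound has an aromatic ring in this group, so the effect of adding one remains untested.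

The closest guide is the modest size of a 3.2-fold higher number from compound 1 to compound 2 (0.51 log units; beyond the scatter), and a rise of similar size seems most likely. The expected change is a 3.0-fold higher number from compound 3 to compound 4 (0.48 log units; beyond the scatter). For compound 4, the estimated value in this assay is 45 nM, with an expected range of 12 nM to 200 nM.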

Compound 4, half-maximal inhibitory concentration: 200 nM
The estimate for compound 4 lay 4.4-fold (0.65 log units) below the measured number, and the stated range covers the measured number.
By their numbers in this assay, from the lowest: compound 3; then compounds 4 and 1 (each within the scatter of the next); then compound 2.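

In this assay, for the compounds shown here, keeping the carboxy group is not enough to hold the low number of compound 3: placing (4-bromophenyl)(carboxy)methyl on this nitrogen instead of 1-carboxyethyl gives a 13-fold higher number from compound 3 to compound 4 (1.12 log units; beyond the scatter) and shows for the first time that an aromatic ring in this group can bring a large change. The carboxy-bearing compound 4 also gives up most of the earlier advantage over the ester-bearing compounds, with a 4.0-fold lower number from compound 2 to compound 4 (0.60 log units; beyond the scatter) leaving only a modest step, while a 1.3-fold lower number from compound 1 to compound 4 (0.10 log units; within the scatter) shows no difference that can be told from ordinary assay variation. Nothing measured here explains why the numbers move this way.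

The entering group adds both a six-membered aromatic ring and a bromine, and the compounds shown cannot separate these two changes, so a plain phenyl group or a 4-chlorophenyl group on the same carboxy-bearing carbon would be informative. As far as these compounds go, compound 3 also has a defined stereocentre in this group whereas compound 4 has none, so the part played by the spatial arrangement at this carbon remains open as well.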